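Expecting Compound 3: A 4-Hydroxybenzyl Group on the Amide

A few compounds are considered here, and "the series" means these few. Any claim that something is new, unique, unknown or untested is made for them only; others in the source may bear on it.

Of the compounds shown here, two on the shared core have been measured in an ADME assay on MT4 cells (Homo sapiens) for cytotoxicity, read by MTT assay; a lower number here means that less compound is tolerated, a higher number that more compound is tolerated. Compound 1 (`Cc1cc(C)cc(S(=O)(=O)c2c(C(=O)NCc3ccccc3O)[nH]c3ccc(Cl)cc23)c1`) gives 23800 nM, and compound 2 (`Cc1cc(C)cc(S(=O)(=O)c2c(C(=O)NC(C)c3ccccc3O)[nH]c3ccc(Cl)cc23)c1`) gives 21800 nM. These two numbers lie within the scatter of each other, so compound 2 stands with compound 1 and the two cannot be told apart. Among the compounds with values here, the only measured step, a 1.1-fold lower number from compound 1 to compound 2 (0.04 log units; within the scatter), places a methyl for a hydrogen on the saturated chain carbon bound to the amide-type nitrogen, and it stays within the scatter.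

The unmeasured compound 3 (`Cc1cc(C)cc(S(=O)(=O)c2c(C(=O)NCc3ccc(O)cc3)[nH]c3ccc(Cl)cc23)c1`) carries a 4-hydroxybenzyl group on the amide-type nitrogen: a group of 8 heavy atoms (7 carbon, 1 oxygen; one six-membered aromatic ring of carbon only) in place of a group of 9 heavy atoms (8 carbon, 1 oxygen; one six-membered aromatic ring of carbon only), on an amide-type nitrogen. Within the data shown here, the measured step covers only part of this change, and no measured compound yet carries the 4-hydroxybenzyl group. Among the measured compounds shown here, with only that small step from compound 1 to go on, no shift beyond the scatter is expected in this assay, though the evidence is thin. The expected size is a 1.0-fold higher number from compound 2 to compound 3 (0.00 log units; within the scatter). Compound 3 is estimated at 22000 nM, with an expected range of 9000 nM to 50000 nM.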

Compound 3, half-maximal cytotoxic concentration: 6250 nM
Compound 3: middle estimate off by 3.5-fold (0.55 log units), on the high side; the whole stated range lies above it.
By their numbers in this assay, from the lowest: compound 3; then compounds 2 and 1 (each within the scatter of the next).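

In this assay, 4-hydroxyphenyl in place of 2-hydroxyphenyl on the saturated chain carbon bound to the amide-type nitrogen gives a 3.8-fold lower number from compound 1 to compound 3 (0.58 log units; beyond the scatter), so this position can move the number beyond the scatter, which the methyl step, a 1.1-fold lower number from compound 1 to compound 2 (0.04 log units; within the scatter), did not show. The step of a 3.5-fold lower number from compound 2 to compound 3 (0.54 log units; beyond the scatter) is printed as beyond the scatter too, but it replaces the whole group on the amide-type nitrogen, so it changes the methyl-bearing chain carbon as well as the hydroxyphenyl group; compound 3 has the lowest number of the three, and less of it is tolerated by the cells. No measured evidence gives a reason for this shift.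

The compounds shown leave open whether the lower number follows the 4-hydroxyphenyl group specifically or would also appear with a plain benzyl or a 4-methoxybenzyl group on the amide-type nitrogen. They also leave open whether a methyl on the chain carbon would change the number with the 4-hydroxyphenyl group in place, as it did not with the 2-hydroxyphenyl group.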